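A few compounds are considered here, and "the series" means these few. Any claim that something is new, unique, unknown or untested is made for them only; others in the source may bear on it.

Measured in a functional assay on A549 cells (Homo sapiens) for antiproliferative activity, read by sulforhodamine B assay, with a stated time of 48 h, tested at 10 uM; on this read-out lower numbers stand for less inhibition and higher numbers for more inhibition at the one concentration tested (going by the name of the read-out):
compound 1 `CCCCCCCCCCCCCC[C@H](OCOC)[C@H](CN(CC)CC)NC(=O)OC(C)(C)C` — 27.5%
compound 2 `CCCCCCCCCCCCCC[C@H](OCOC)[C@H](CN(CCCC)CCCC)NC(=O)OC(C)(C)C` — 42.2%
compound 3 `CCCCCCCCCCCCCC[C@H](O)[C@H](CN(CC)CC)NC(=O)OC(C)(C)C` — 18.5%

Compound 3 stands lowest of the three numbers in this assay; the nearest is compound 1, with the step of a number 9 percentage points lower from compound 1 to compound 3 (within the scatter), and the furthest is compound 2, beyond the scatter. Compound 4 `CCCCCCCCCCCCCC[C@H](O)[C@H](CN(CCCC)CCCC)NC(=O)OC(C)(C)C` has not been measured. It differs from compound 3 by dibutylamino in place of diethylamino on a saturated chain carbon, two bonds along the chain from an amide-type nitrogen. The single measured step bearing on this change is a number 14.7 percentage points higher from compound 1 to compound 2 (beyond the scatter), a modest rise beyond the scatter; no second example of the change exists among these compounds. Carrying a step of that size onto compound 3, compound 4 is expected to move by a number 14.5 percentage points higher from compound 3 to compound 4 (beyond the scatter) in this assay, upward and beyond the scatter. The estimate for compound 4 in this assay is 33%, with a range from 22% to 45%.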

Compound 4, a percentage reported as inhibition, at one concentration (the size of the read-out at that concentration, not a potency): 30%
Beside the measured number, compound 4's estimate is 3 percentage points above it; measured number inside the range.
By their numbers in this assay, from the lowest: compounds 3, 1 and 4 (each within the scatter of the next, the first and the last beyond it); then compound 2.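

In this assay, dibutylamino in place of diethylamino now has a second example, giving a number 11.5 percentage points higher from compound 3 to compound 4 (beyond the scatter), so the rise holds with the free hydroxyl as well as with the methoxymethyl ether: the same change on two cores in this assay, a number 14.7 percentage points higher (beyond the scatter) from compound 1 to compound 2 and a number 11.5 percentage points higher (beyond the scatter) from compound 3 to compound 4, 3.2 percentage points apart, within the scatter of two such steps
Hydrogen in place of methoxymethyl gives a number 12.2 percentage points lower from compound 2 to compound 4 (beyond the scatter), beyond the scatter where the step on the diethylamino pair was not, yet the two steps agree: the same change on two cores in this assay, a number 9 percentage points lower (within the scatter) from compound 1 to compound 3 and a number 12.2 percentage points lower (beyond the scatter) from compound 2 to compound 4, 3.2 percentage points apart, within the scatter of two such steps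
Across these four compounds, the two changes therefore read as independent of each other.

Still open, going by these compounds, is whether dihexylamino or a ring amine such as piperidine extends the rise. On these data alone, the effect of replacing the tert-butyl carbamate with a free primary amine is also open.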